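The source may hold more compounds than are shown below. What is called first, only, known or untested is meant among the compounds shown, and "the series" means these compounds.

Working notes on the series in a functional assay on LoVo cells (Homo sapiens) for inhibition, read by MTT assay, with a stated time of 24 h; on this read-out lower numbers stand for stronger inhibition and higher numbers for weaker inhibition.

Of the compounds shown here, two carry numbers so far. Compound 1 `CC1(C)[C@H]2CC[C@]1(C)N(Cc1cn(-c3ccccc3C#N)nn1)C(=O)C2` gives 140 nM in this assay. Compound 2 `Cc1ccc(-n2cc(CN3C(=O)C[C@@H]4CC[C@@]3(C)C4(C)C)nn2)cc1` gives 50 nM in this assay. Among the compounds with values here, the single measured step is a 2.8-fold lower number from compound 1 to compound 2 (0.45 log units; beyond the scatter), the one change there being 4-methylphenyl in place of 2-cyanophenyl on an aromatic nitrogen. Compound 2 stands lowest of the two numbers shown, with compound 1 the only neighbour and its number higher by that same step.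

Compound 3 `Cc1cccc(-n2cc(CN3C(=O)C[C@@H]4CC[C@@]3(C)C4(C)C)nn2)c1` is the next member: 3-methylphenyl in place of 4-methylphenyl on an aromatic nitrogen. The two structures hold the same atoms, joined differently, so the shared core and the triazole are untouched. Within the data shown here, no measured step in this assay moves a methyl group around a phenyl ring; the step from compound 1 to compound 2 swaps both the group and its place at once and so bears only loosely on this change. Without a closer precedent, no step beyond the scatter is expected in this assay for compound 3, the estimated step being a 1.2-fold higher number from compound 2 to compound 3 (0.08 log units; within the scatter). The estimate for compound 3 in this assay is 60 nM, with a range of 25 nM to 150 nM.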

Compound 3, half-maximal inhibitory concentration: 50 nM
Compound 3: middle estimate off by 1.2-fold (0.08 log units), on the high side; low and high end bracket the measured number.
By their numbers in this assay, from the lowest: compounds 2 and 3 (each within the scatter of the next); then compound 1.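

In this assay, moving the methyl group from 4-methylphenyl to 3-methylphenyl on the aromatic nitrogen gives no change at the digits printed from compound 2 to compound 3 (within the scatter), the first read on placement in this series, and across these two methylphenyl isomers the place of the methyl group leaves the number unchanged within the scatter. The comparison with the nitrile-bearing compound gives a 2.8-fold lower number from compound 1 to compound 3 (0.45 log units; beyond the scatter), so the gain seen earlier with 4-methylphenyl is matched by 3-methylphenyl, and both methylphenyl compounds lie on the same side of compound 1 by a modest margin. No supporting data are available to explain either the flat response to moving the methyl group or the gap to 2-cyanophenyl.

The compounds shown do not separate the effect of the group from that of its place in the 2-cyanophenyl comparison, a question that 2-methylphenyl and 4-cyanophenyl would address directly. They also leave open whether the tolerance seen for methyl extends to a carboxylic acid, an amine or a longer chain such as butyl on the same phenyl ring.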